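Heteroaryl swap on the shared core of compound 2

The source may report more compounds than this note shows. Statements on the series, on what has been measured and on what is new or still open speak of the compounds shown alone.

Measured so far:
- compound 1 `Oc1ccccc1-c1cc(-c2ccsc2)cc(-c2ccccc2O)n1`: > 50000 nM in a functional assay on T47D cells (Homo sapiens) for cytotoxicity, read by CCK-8 assay; a lower number here means a stronger inhibitor, a higher number a weaker inhibitor
- compound 2 `Oc1cccc(-c2cc(-c3ccsc3)cc(-c3ccccc3O)n2)c1`: > 50000 nM in this assay
- compound 3 `Oc1ccc(-c2cc(-c3ccsc3)cc(-c3cccc(O)c3)n2)cc1`: 760 nM in this assay

The value given for compound 1 is a limit of this assay, not a number. The value given for compound 2 is likewise a limit of this assay, not a number. Among the compounds with values here, compound 3 is the only compound of the three with a numerical reading, and it is the low one.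

Two steps are measured. The step that the two limits leave unreadable from compound 1 to compound 2 cannot be sized, since both ends sit at a limit; this is the situation summarised by the limit of > 50000 nM in this assay, at which 2 of the 3 values shown sit. Within the data shown here, the step of an at least 65-fold lower number from compound 2 to compound 3 (1.81 log units; beyond the scatter) is large and is the only step of readable size. Neither of these steps touches the five-membered ring, so neither bears directly on the change now in question.

Compound 4 `Oc1cccc(-c2cc(-c3ccco3)cc(-c3ccccc3O)n2)c1` differs from compound 2 in the change (furan-2-yl in place of thiophen-3-yl on an aromatic carbon). Among the measured compounds shown here, with no measured step speaking to this change, a step beyond the scatter is not expected, and compound 2 stands at the limit. The expected step is a number no higher from compound 2 to compound 4 (the limit leaves the size open). For compound 4 the estimate in this assay is 50000 nM, with a range from 15000 nM to 150000 nM.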

Compound 4, half-maximal inhibitory concentration: 820 nM
Compound 4: middle estimate off by 61-fold (1.79 log units), on the high side; the measured number lies below the stated range.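

In this assay, the position opposite the ring nitrogen proves sensitive to the identity of the five-membered ring: an at least 60-fold lower number from compound 2 to compound 4 (1.78 log units; beyond the scatter). Until now, the series had shown only changes to the hydroxyphenyl groups, one of them a step that cannot be read, all with thiophen-3-yl held constant; this result adds a change at the five-membered ring, where thiophen-3-yl and furan-2-yl match in heavy atoms, hydrogen-bond donors and hydrogen-bond acceptors, so those counts do not separate the two compounds. Compound 2 stands at a limit rather than a number, and the true size of this step stays open because of that limit: the limit of > 50000 nM in this assay, at which 2 of the 4 values shown sit.

The swap replaces sulfur with oxygen and also moves the point of attachment, so the two contributions cannot be separated here; furan-3-yl and thiophen-2-yl at this position would separate them. Also open, as far as these compounds go, is whether furan-2-yl gives a similar result with the hydroxyphenyl arrangements of compound 1 and compound 3, and how a pyridin-3-yl ring or an open aminomethyl group would read at this position.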